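Working notes: a bromo step from compound 1

The source may hold more compounds than are shown below. What is called first, only, known or untested is meant among the compounds shown, and "the series" means these compounds.

In a functional assay on the whole organism for inhibition, with Felis catus as the target, with a stated time of 30 min (on this read-out lower numbers stand for an effect already at smaller amounts and higher numbers for an effect only at larger amounts of compound), compound 1 `OC(CNCCOc1ccccc1)COc1ccccc1` gives 0.054 mg/kg. Compound 2 `COc1ccc(OCCNCC(O)COc2ccccc2)cc1` gives 0.064 mg/kg, and compound 3 `OC(CNCCOc1ccccc1F)COc1ccccc1` gives 0.081 mg/kg. Neither of these two is separated from compound 1 by more than the scatter, so compound 1 holds no distinct place among the measured numbers.

The next compound is compound 4 `OC(CNCCOc1ccccc1)COc1ccccc1Br`, still unmeasured. Its structural change from compound 1 is bromo in place of hydrogen on an aromatic carbon, ortho to a large group.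

Within the data shown here, two measured steps bear on this change, as both replace a hydrogen on an aromatic carbon. The methoxy change gives a 1.2-fold higher number from compound 1 to compound 2 (0.07 log units; within the scatter), and the fluoro change gives a 1.5-fold higher number from compound 1 to compound 3 (0.18 log units; within the scatter). Among the measured compounds shown here, neither change places a group on the ring that takes the bromo in compound 4, and no bromo compound has been measured, so the support is indirect. With only these two small steps as a guide, no shift beyond the scatter is expected in this assay, although a slightly higher number remains possible. The expected step is a 1.3-fold higher number from compound 1 to compound 4 (0.11 log units; within the scatter). For compound 4 the estimated value is 0.07 mg/kg, with an expected range from 0.03 mg/kg to 0.18 mg/kg.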

Compound 4, dose for half-maximal effect: 0.3 mg/kg
The estimate for compound 4 lay 4.3-fold (0.63 log units) below the measured number, outside the stated range (above it).
By their numbers in this assay, from the lowest: compounds 1, 2 and 3 (each within the scatter of the next); then compound 4.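

In this assay, bromo in place of hydrogen on an aromatic carbon, ortho to a large group, is the only change among those shown with a step beyond the scatter: a 5.6-fold higher number from compound 1 to compound 4 (0.74 log units; beyond the scatter). The methoxy and fluoro changes, with a 1.2-fold higher number from compound 1 to compound 2 (0.07 log units; within the scatter) and a 1.5-fold higher number from compound 1 to compound 3 (0.18 log units; within the scatter), stay within the scatter, and neither places a group on the ring that takes the bromo, so they gave no reading of this ring; the new step shows that a substituent here can move the number to a higher value, towards an effect only at larger amounts of compound. Nothing available bears on the reason for this step, which therefore stands as an observation on one compound and one substituent.

The compounds shown leave open whether the step belongs to bromo itself or to any group at this place, a question that chloro, methyl or nitrile on the same aromatic carbon would address. They also leave open how the same ring responds to bromo at its other carbons, and whether hydroxy or an amine there would give a step of similar size in this read-out.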